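Swapping the amide substituent on a saturated tail

The compounds below may be only part of what the source reports. "The series", "measured", "known", "first", "only" and "open" are said of these compounds alone.

Three compounds measured so far in an assay for inhibition of RAC-alpha serine/threonine-protein kinase (Homo sapiens), read by HTRF, with a stated time of 1 h; a lower number here means a stronger inhibitor, a higher number a weaker inhibitor:
Compound 1, `Cn1ncc(Cl)c1-c1cc(C(=O)N[C@@H]2CN[C@H](CCn3cncn3)C[C@H]2c2ccc(Cl)c(Cl)c2)oc1Cl`, gives 4.47 nM.
Compound 2, `Cn1ncc(Cl)c1-c1cc(C(=O)N[C@@H]2CN[C@H](CCN3CCCCC3)C[C@H]2c2ccc(Cl)c(Cl)c2)oc1Cl`, gives 5.65 nM.
Compound 3, `Cn1ncc(Cl)c1-c1cc(C(=O)N[C@@H]2CN[C@H](CC(=O)NC3CC3)C[C@H]2c2ccc(Cl)c(Cl)c2)oc1Cl`, gives 3.95 nM.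

Compound 3 has the smallest of the three numbers, but its steps from the others, a 1.1-fold lower number from compound 1 to compound 3 (0.05 log units; within the scatter) and a 1.4-fold lower number from compound 2 to compound 3 (0.16 log units; within the scatter), lie within the scatter, so the three cannot be ranked. Compound 4, `Cn1ncc(Cl)c1-c1cc(C(=O)N[C@@H]2CN[C@H](CC(=O)NCCO)C[C@H]2c2ccc(Cl)c(Cl)c2)oc1Cl`, differs from compound 3 by 2-hydroxyethyl in place of cyclopropyl on an amide-type nitrogen. For the measured compounds named here, no measured step alters this amide nitrogen itself; the closest comparisons are the exchanges on the chain, a 1.3-fold higher number from compound 1 to compound 2 (0.10 log units; within the scatter) and a 1.4-fold lower number from compound 2 to compound 3 (0.16 log units; within the scatter), both within the scatter. Varying this tail has moved the number little, so the expected step is a 1.1-fold higher number from compound 3 to compound 4 (0.06 log units; within the scatter). Compound 4 is estimated at 4.5 nM, between 2 nM and 10 nM.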

Compound 4, half-maximal inhibitory concentration: 1.41 nM
Estimate against measurement, compound 4: 3.2-fold (0.50 log units) above; measured number below the stated range.
By their numbers in this assay, from the lowest: compound 4; then compounds 3, 1 and 2 (each within the scatter of the next).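

The tail exchanges seen earlier all stayed within the scatter, but 2-hydroxyethyl in place of cyclopropyl on the amide-type nitrogen gives a 2.8-fold lower number from compound 3 to compound 4 (0.45 log units; beyond the scatter) and so moves the number beyond it. Compound 4 also stands clear of the two compounds with other tails, with a 4.0-fold lower number from compound 2 to compound 4 (0.60 log units; beyond the scatter) and a 3.2-fold lower number from compound 1 to compound 4 (0.50 log units; beyond the scatter), so the substituent on this nitrogen can change the number. Nothing measured here accounts for this step. Still open, from the compounds shown here alone, is whether the step follows from the hydroxyl or from losing the ring: an ethyl group, a 2-methoxyethyl group or a longer 3-hydroxypropyl chain on this nitrogen would help separate the two.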